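Shortening the Chain of Compound 1

A few compounds are considered here, and "the series" means these few. Any claim that something is new, unique, unknown or untested is made for them only; others in the source may bear on it.

Within the data shown here, only two compounds have been measured so far. In a physicochemical assay for lipophilicity, measured as octanol-water partition (on this read-out lower numbers stand for lower lipophilicity and higher numbers for higher lipophilicity), compound 1 (`CC(C)CC(=O)Nc1nc2ccccc2s1`) gives 3.54, while compound 2 (`c1ccc(CNc2nc3ccccc3s2)cc1`) gives 4.46. That gap lies beyond the scatter, so compound 1 holds the lower of the two numbers.

The next compound, compound 3 (`CC(=O)Nc1nc2ccccc2s1`), has not yet been measured. It differs from compound 1 in one place: hydrogen in place of isopropyl on a saturated chain carbon bound to a carbonyl carbon, with hydrogen in place of isopropyl on a saturated chain carbon bound to a carbonyl carbon. The same difference can also be read as isobutyl to methyl.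

Among the measured compounds shown here, no pair of measured compounds shows this change, so the expectation rests on the structures alone. The estimated step is a number 1.34 log units lower from compound 1 to compound 3 (beyond the scatter), a fall in this assay that is expected to lie beyond the scatter. For compound 3 the estimated value is 2.2, with an expected range of 1.8 to 2.6.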

Compound 3, partition coefficient: 2.14
Beside the measured number, compound 3's estimate is 0.06 log units above it; the range from low to high includes it.
By their numbers in this assay, from the lowest: compound 3; then compound 1; then compound 2.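

Among these compounds, this is the first step seen at this position: hydrogen in place of isopropyl on a saturated chain carbon bound to a carbonyl carbon, also readable as isobutyl to methyl, gives a number 1.40 log units lower from compound 1 to compound 3 (beyond the scatter) in this assay. The group that leaves holds only carbon, with no ring, no net charge and no hydrogen-bond donors or acceptors, so a change limited to this carbon chain is enough to produce a large step. Nothing available explains the size of this step.

The compounds shown leave open how the number responds to other groups at this place, such as an ethyl group, a longer chain, an amine or a carboxylic acid. They also leave open whether the same change would give a similar step on a different core.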